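This account rests on a few compounds, and the source may have more. Where it says the series, first, only, none or still open, it means among the compounds named here.

compound 1 `O=C1C=CCCN1C(=O)/C=C/c1ccccc1`: 3500 nM
compound 2 `COc1ccccc1/C=C/C(=O)N1CCC=CC1=O`: 9600 nM
compound 3 `COc1ccc(/C=C/C(=O)N2CCC=CC2=O)cc1`: 8200 nM

All three values come from a functional assay on MCF7 cells (Homo sapiens) for antiproliferative activity, read by resazurin assay, with a stated time of 48 h; on this read-out higher numbers stand for weaker inhibition and lower numbers for stronger inhibition. Compound 3 lies within the scatter of compound 2, and both carry clearly higher numbers than compound 1. Its distance from the unsubstituted compound is a 2.3-fold higher number from compound 1 to compound 3 (0.37 log units; beyond the scatter).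

The next compound is compound 4 `COc1ccc(/C=C/C(=O)N2CCC=CC2=O)c(OC)c1`, which differs from compound 3 by methoxy in place of hydrogen on an aromatic carbon. The new group sits ortho to a large group and meta to a methoxy group.

For the measured compounds named here, two measured steps bear on this change, both of the same kind. One is a 2.7-fold higher number from compound 1 to compound 2 (0.44 log units; beyond the scatter), and the other is a 2.3-fold higher number from compound 1 to compound 3 (0.37 log units; beyond the scatter). Both are modest and both run towards weaker inhibition. Compound 2 is the closer guide, since its methoxy also stands ortho to a large group. Neither step shows what a second methoxy does, so simple addition is uncertain, and the range is kept wide.

A modest further rise in this assay is expected, slightly smaller than the measured steps. The expected step is a 2.1-fold higher number from compound 3 to compound 4 (0.32 log units; beyond the scatter). For compound 4 the estimated value is 17000 nM, with an expected range from 7000 nM to 38000 nM.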

Compound 4, half-maximal inhibitory concentration: 8500 nM
Beside the measured number, compound 4's estimate is 2.0-fold (0.30 log units) above it; the measured number falls inside the stated range.
By their numbers in this assay, from the lowest: compound 1; then compounds 3, 4 and 2 (each within the scatter of the next).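

In this assay, methoxy in place of hydrogen on an aromatic carbon, ortho to a large group and meta to a methoxy group, gives a 1.0-fold higher number from compound 3 to compound 4 (0.02 log units; within the scatter), so on a ring that already carries a methoxy group this position shows no measurable cost. Reached from compound 2 instead, the same change gives a 1.1-fold lower number from compound 2 to compound 4 (0.05 log units; within the scatter), and the two placements of the methoxy group together cost no more than either one alone. The steps that start from the unsubstituted ring of compound 1 lie beyond the scatter and those that start from a methoxy-bearing ring do not, yet the gap between them is too small to establish that the effect of this change depends on the starting compound: the same change on two cores in this assay, a 2.7-fold higher number (0.44 log units; beyond the scatter) from compound 1 to compound 2 and a 1.0-fold higher number (0.02 log units; within the scatter) from compound 3 to compound 4, 2.6-fold (0.42 log units) apart, within the scatter of two such steps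

The compounds shown carry only methoxy on the ring, so it remains open whether a hydroxy group, a fluorine atom, an amine or a longer ethoxy chain at this position would behave in the same way. As far as these compounds go, it also remains open whether any ring substituent can give a lower number than the unsubstituted compound 1 at 3500 nM.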